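The compounds below may be only part of what the source reports. "The series", "measured", "known", "first", "only" and "open" are said of these compounds alone.

In a functional assay on MCF7 cells (Homo sapiens) for antiproliferative activity, read by MTT assay, with a stated time of 72 h (a lower number here means a stronger inhibitor, a higher number a weaker inhibitor), three compounds have results so far. Compound 1 `CC(C)N1C(=O)COc2ccc(-c3cnc(Cl)c(NS(=O)(=O)c4ccc(F)cc4)c3)cc21` gives 26600 nM and compound 3 `COc1ncc(-c2ccc3c(c2)N(c2ccc(Cl)cc2)C(=O)CO3)cc1NS(=O)(=O)c1ccc(F)cc1` gives 27600 nM, two values that lie within the scatter of each other. Compound 2 `Cc1ccc(N2C(=O)COc3ccc(-c4cnc5ccccc5c4)cc32)cc1` has no exact figure, as its result of > 40000 nM is a limit and not a number.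

Compound 4 `O=C1COc2ccc(-c3cnc4ccccc4c3)cc2N1c1ccccc1` is compound 2 with a single small edit: hydrogen in place of methyl on an aromatic carbon. In words, hydrogen takes the place of methyl on an aromatic carbon, para to a large group, so 4-methylphenyl becomes phenyl while the rest of the structure stays the same. Going by the values given here, no measured pair here differs in only one place, so the data do not yet show what an edit of this kind does in this assay.

The nearest guide is compound 2, with its limit of > 40000 nM. Compound 4 is therefore expected to stay in the same weak region, with no change beyond the scatter in either direction. The expected size of an at least 1.0-fold lower number from compound 2 to compound 4 (0.02 log units; that floor lies within the scatter) is small. It may well be reported only as a limit again. For compound 4 the estimated value is 38000 nM, with an expected range from 15000 nM to 80000 nM.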

Compound 4, half-maximal inhibitory concentration: > 40000 nM
Compound 4: a limit, no number (the forecaster's own chance of this, stated with the estimate: 60%); middle value at least 1.0-fold (0.02 log units) away from the limit.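

Compound 4 gives > 40000 nM, a limit and not a number, so with compound 2 also resting on a limit, no step can be read between compound 2 and compound 4. Both results stop at the same point: the limit of > 40000 nM in this assay, at which 2 of the 4 values shown sit.

The compounds shown leave open what changing 4-methylphenyl to phenyl does in this assay.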